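The source may report more compounds than this note shows. Statements on the series, on what has been measured and on what is new or still open speak of the compounds shown alone.

Working notes on the series. In a functional assay on HepG2 cells (Homo sapiens) for cytotoxicity, read by MTT assay (on this read-out higher numbers stand for weaker inhibition and lower numbers for stronger inhibition), compound 1 `COc1ccc(/C=C/C(=O)c2ccc(OC)c3c2OC(C)(C)C=C3)cc1O` gives 450 nM. Compound 2 `C=CCOc1cc(/C=C/C(=O)c2ccc(OC)c3c2OC(C)(C)C=C3)ccc1OC` reads > 10000 nM, and this value is a limit of the assay. Going by the values given here, compound 3 `CCCCC(=O)Oc1cc(/C=C/C(=O)c2ccc(OC)c3c2OC(C)(C)C=C3)ccc1OC` gives 100 nM, the lowest number so far, with compound 1 as its nearest neighbour among the exact values.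

The next change leads to compound 4 `COc1ccc(/C=C/C(=O)c2ccc(OC)c3c2OC(C)(C)C=C3)cc1OC(=O)C1CC1`: cyclopropyl in place of butyl on a carbonyl carbon. In words, cyclopropyl stands in place of butyl on a carbonyl carbon, so the carbonyl on the oxygen stays. Among the compounds with values here, no measured step varies the group on that carbonyl carbon, so the evidence is indirect. Butylcarbonyl in place of hydrogen gives a 4.5-fold lower number from compound 1 to compound 3 (0.65 log units; beyond the scatter), a modest step. Allyl in place of hydrogen gives an at least 22-fold higher number from compound 1 to compound 2 (1.34 log units; beyond the scatter), a large one, and butylcarbonyl in place of allyl gives an at least 100-fold lower number from compound 2 to compound 3 (2.00 log units; beyond the scatter), also large. The large steps both involve the allyl compound, which has no carbonyl on that oxygen, whereas compound 4 keeps it. In this assay, the expected result is therefore a 1.5-fold higher number from compound 3 to compound 4 (0.18 log units; within the scatter), probably no step beyond the scatter, with a slight lean towards a higher number. For compound 4 the estimate is 150 nM, with an expected range of 50 nM to 500 nM.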

Compound 4, half-maximal inhibitory concentration: 220 nM
Compound 4: middle estimate off by 1.5-fold (0.17 log units), on the low side; the range from low to high includes it.
By their numbers in this assay, from the lowest: compound 3; then compound 4; then compound 1. At a limit, above all of these: compound 2.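

In this assay, the group on the carbonyl carbon turns out to matter in its own right: cyclopropyl in place of butyl gives a 2.2-fold higher number from compound 3 to compound 4 (0.34 log units; beyond the scatter), so the result at this oxygen depends on more than the presence of the carbonyl. A second group on that carbonyl still stands on the low side of the compound with hydrogen on the oxygen, with cyclopropylcarbonyl in place of hydrogen giving a 2.0-fold lower number from compound 1 to compound 4 (0.31 log units; beyond the scatter), though by a smaller step than butylcarbonyl gives. Against the allyl compound the separation is again wide, at an at least 45-fold lower number from compound 2 to compound 4 (1.65 log units; beyond the scatter), and this step is open-ended, as the value of compound 2 is a limit: the limit of > 10000 nM in this assay, at which 1 of the 4 values shown sits.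

Butyl and cyclopropyl differ both in carbon count and in the ring, so it stays open which of the two goes with the higher number; a straight propyl chain on the carbonyl carbon would separate them, and a longer chain such as hexyl would show whether the trend with chain length continues. Also open is how an amine on the carbonyl carbon, giving a carbamate, would compare with the two carbon groups shown.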